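A Single Aryl Swap on a Shared Amide Core

The source may report more compounds than this note shows. Statements on the series, on what has been measured and on what is new or still open speak of the compounds shown alone.

Compound 1 `Cc1nc(-c2ccccc2)c(C(=O)N2CCN(c3cccc(C#N)c3)CC2)o1` — 39.6 nM
Compound 2 `COc1cccc(N2CCN(C(=O)c3oc(C)nc3-c3ccccc3F)CC2)c1` — 56.1 nM

Both were tested in a functional assay on HL-60 cells (Homo sapiens) for inhibition, read by MTT assay, with a stated time of 72 h; a lower number here means a stronger inhibitor, a higher number a weaker inhibitor. Compound 1 gives the lowest of the two numbers, but compound 2 lies within the scatter of it, so no order between them can be claimed. Compound 3 `Cc1nc(-c2ccccc2)c(C(=O)N2CCN(c3ccccc3F)CC2)o1` is not yet measured; it differs from compound 1 by 2-fluorophenyl in place of 3-cyanophenyl on an amine nitrogen in a ring. Among the measured compounds shown here, no measured pair covers this change, so the expected step of a 1.4-fold higher number from compound 1 to compound 3 (0.14 log units; within the scatter) is small, within the scatter, with no direction to be read from the data. Compound 3 is estimated at 55 nM, in a range from 18 nM to 170 nM.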

Compound 3, half-maximal inhibitory concentration: 147 nM
Compound 3: middle estimate off by 2.7-fold (0.43 log units), on the low side; the range from low to high includes it.
By their numbers in this assay, from the lowest: compounds 1 and 2 (each within the scatter of the next); then compound 3.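

In this assay, among the compounds shown here, the aryl group on the amine nitrogen of the shared core matters: 2-fluorophenyl in place of 3-cyanophenyl gives a 3.7-fold higher number from compound 1 to compound 3 (0.57 log units; beyond the scatter), a step beyond the scatter and the first readable change in this set. The swap alters both the substituent and its numbered place on the phenyl ring, so this single step cannot separate the two. From the compounds shown here alone, whether plain phenyl, 3-fluorophenyl or 2-cyanophenyl would sit nearer compound 1 or compound 3 remains open. No measurement shown here explains the step.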